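The compounds below may be only part of what the source reports. "The series", "measured", "known", "first", "only" and "open" are said of these compounds alone.

Measured so far:
- compound 1 `Cc1cccc(C(=O)N2CCCC(C(=O)Nc3ccc(Cl)cc3)C2)c1`: 0%
- compound 2 `O=C(Nc1cccc(Oc2ccccn2)c1)C1CCCN(C(=O)c2cc(C(F)(F)F)cc(C(F)(F)F)c2)C1`: 0%
- compound 3 `O=C(Nc1cccc(Cc2ccccc2)c1)C1CCCN(C(=O)c2cccc(-c3ccco3)c2)C1`: 0%

The three compounds were tested in an ADME assay on PC-3 cells (Homo sapiens) for cytotoxicity, read by WST assay, tested at 100 uM; on this read-out lower numbers stand for less inhibition and higher numbers for more inhibition at the one concentration tested (going by the name of the read-out). Among the measured compounds shown here, on these numbers compound 2 stands level with compounds 1 and 3 at the digits reported; its nearest neighbour is compound 1 and its furthest is compound 3, and in both cases the difference lies within the scatter, so no compound can be called more or less cytotoxic than another here. Compound 4 `O=C(Nc1cccc(Oc2ccccc2)c1)C1CCCN(C(=O)c2cc(C(F)(F)F)cc(C(F)(F)F)c2)C1` has not yet been measured in this assay. It differs from compound 2 in one place: phenyl in place of pyridin-2-yl on an oxygen on an aromatic ring. For the measured compounds named here, no step between measured compounds that differ in one place has been recorded, so the size of this step rests on the three values alone. Since every measured compound shows no inhibition at the single concentration, the step in this assay is expected to lie within the scatter, with no direction beyond it. Compound 4 is therefore expected to give 0%, ranging from 0% to 10%, which is an expected step of no change at the digits printed from compound 2 to compound 4 (within the scatter) from compound 2.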

Compound 4, a percentage reported as inhibition, at one concentration (the size of the read-out at that concentration, not a potency): 1%
The estimate for compound 4 lay 1 percentage points below the measured number, within the range that was stated.
By their numbers in this assay, from the lowest: compounds 1, 2, 3 and 4 (each within the scatter of the next).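

Among the compounds shown here, the change of pyridin-2-yl to phenyl on an oxygen on an aromatic ring is the only one-place comparison available in this assay, and it gives a number 1 percentage points higher from compound 2 to compound 4 (within the scatter). At this position, then, the two aromatic rings cannot be told apart at the one concentration tested, even though phenyl carries no ring nitrogen and no hydrogen-bond acceptor. No measurement at hand bears on why the two compounds read alike.

As far as these compounds go, whether an amine or a carboxylic acid in place of phenyl on that oxygen would move the read-out beyond the scatter remains open. Also open, from the compounds shown here alone, is whether compound 2 and compound 4 would separate at any other concentration, or whether a one-place change elsewhere on the shared core would separate such compounds.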